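A few compounds are considered here, and "the series" means these few. Any claim that something is new, unique, unknown or untested is made for them only; others in the source may bear on it.

Three thiosemicarbazones with a measured antiproliferative number set the scene. Compound 1 `FC(F)(F)c1ccccc1NC(=S)N/N=C/c1ccc2ccccc2n1` gives 13200 nM in a functional assay on HL-60 cells (Homo sapiens) for antiproliferative activity, read by sulforhodamine B assay, with a stated time of 72 h; a lower number here means a stronger inhibitor, a higher number a weaker inhibitor. Compound 2 `S=C(NCc1ccccc1)N/N=C/c1ccc2ccccc2n1` gives 21900 nM in this assay, and its number lies within the scatter of compound 1, so the two cannot be ordered. Compound 3 `NC(=S)N/N=C/c1nc2ccccc2s1` gives > 100000 nM in this assay; this is a limit of the assay and not a number, namely (the limit of > 100000 nM in this assay, at which 1 of the 3 values shown sits).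

No pair among these three differs in one place, so no single measured step exists here. Among the compounds with values here, the one step followed is from compound 2 to the not yet measured compound 4 `COc1cccc(NC(=S)N/N=C/c2ccc3ccccc3n2)c1`. The change is 3-methoxyphenyl in place of benzyl on an amide-type nitrogen, on the nitrogen that carries the thiocarbonyl carbon. Within the data shown here, compound 1 also carries a substituted phenyl on that nitrogen and its number is close to that of compound 2, which is the only guide the three measured compounds offer. The expectation is therefore a step from compound 2 to compound 4 of no more than the scatter, with a slight lean toward a lower number, as a 1.8-fold lower number from compound 2 to compound 4 (0.26 log units; within the scatter) expresses. Compound 4 is expected to give 12000 nM in this assay, within a range from 4000 nM to 40000 nM.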

Compound 4, half-maximal inhibitory concentration: 71200 nM
The estimate for compound 4 lay 5.9-fold (0.77 log units) below the measured number, and the stated range ends below it.
By their numbers in this assay, from the lowest: compounds 1 and 2 (each within the scatter of the next); then compound 4. At a limit, above all of these: compound 3.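

In this assay, within the data shown here, the move on the amide-type nitrogen that carries the thiocarbonyl carbon gives the first step that can be read between two compounds differing in one place: a 3.3-fold higher number from compound 2 to compound 4 (0.51 log units; beyond the scatter). The step is modest but beyond the scatter, so this nitrogen is not indifferent to what it carries, which the three earlier compounds could not show because no two of them differed in one place. The measurements shown give no reason for this step, and the limit recorded for compound 3 has no bearing on it.

The change replaces benzyl with 3-methoxyphenyl, so it alters the link to the ring and adds the methoxy group in a single move, and this one step cannot separate the two. As far as these compounds go, it remains open how a plain phenyl, a longer chain such as 2-phenylethyl, or a phenyl ring carrying an amine or a carboxylic acid on this nitrogen would read in this assay, and whether the methoxy group would give the same step on a benzyl group.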